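A few compounds are considered here, and "the series" means these few. Any claim that something is new, unique, unknown or untested is made for them only; others in the source may bear on it.

Measured so far:
compound 1, `COc1cc(-c2ncccc2C(F)(F)F)ccc1C(=O)Nc1ccc(C(F)(F)F)cc1` — > 4000 nM
compound 2, `O=C(Nc1ccc(C(F)(F)F)cc1)c1ccc(-c2ncccc2C(F)(F)F)nc1O` — > 4000 nM

Both compounds were tested in a functional assay for antagonist activity at transient receptor potential cation channel subfamily V member 1 (Homo sapiens), read by FLIPR; a higher number here means a weaker inhibitor, a lower number a stronger inhibitor. For compound 1 the result is a limit of the assay, not a number: > 4000 nM. For compound 2 the result is likewise only a limit of the assay: > 4000 nM. Compound 2 therefore stands at the limit of > 4000 nM in this assay, at which 2 of the 2 values shown sit, and no number places it within or beyond the scatter of compound 1.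

The next compound, compound 3, `Cc1nc(-c2ncccc2C(F)(F)F)ccc1C(=O)Nc1ccc(C(F)(F)F)cc1`, differs from compound 2 in one place: methyl in place of hydroxy on an aromatic carbon. For the measured compounds named here, no step between measured compounds is known here, and both values shown are limits, so no measured direction can be carried over to compound 3.

In this assay the step is expected to be an at least 2.0-fold lower number from compound 2 to compound 3 (0.30 log units; that floor lies within the scatter), and this expected step is modest rather than large, with its direction uncertain. Compound 3 is estimated at 2000 nM, within a range from 200 nM to 20000 nM.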

Compound 3, half-maximal inhibitory concentration: 259 nM
The estimate for compound 3 lay 7.7-fold (0.89 log units) above the measured number; measured number inside the range.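

At this place on the six-membered aromatic ring with 1 nitrogen, next to the ring nitrogen, the substituent makes a clear difference in this assay: methyl in place of hydroxy gives an at least 15-fold lower number from compound 2 to compound 3 (1.18 log units; beyond the scatter), the only readable step shown. With methyl here, compound 3 yields a number rather than a limit of the assay, so activity at this target can be measured on this core and the position is sensitive to what it carries. Going by these compounds, the true size of the step stays unknown and the printed figure is only a floor, since compound 2 is held by a limit and not by a number: the limit of > 4000 nM in this assay, at which 2 of the 3 values shown sit.

The change removes a hydrogen-bond donor and a hydrogen-bond acceptor and also swaps oxygen for carbon, and the two compounds cannot say whether the step comes from losing hydroxy or from gaining methyl. On these data alone, how an ethyl group, a chlorine atom or an amine at this same place would read in this assay remains open, as does whether methyl is the best group here.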